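The source may hold more compounds than are shown below. What is called first, only, known or untested is meant among the compounds shown, and "the series" means these compounds.

Compound 1 `Oc1cccc2nccc(O)c12` is the starting point here, and it shows no measurable effect on cell growth. In a functional assay on L1210 cells (Mus musculus) for antiproliferative activity (a higher number here means a weaker inhibitor, a lower number a stronger inhibitor), compound 1 gives > 40000 nM, which is a limit of the assay and not a number. Its methoxy relative, compound 2 `COc1cc(O)c2c(O)ccnc2c1`, offers no firmer footing. In this assay, compound 2 gives > 40000 nM, which is also a limit. Taken together, the measurements amount to the limit of > 40000 nM in this assay, at which 2 of the 2 values shown sit.

Compound 3 `Cc1ccc(O)c2c(O)ccnc12` carries a small change to the core of compound 1: methyl in place of hydrogen on an aromatic carbon, para to a hydroxy group (methyl in place of hydrogen on an aromatic carbon). The nearest measured comparison is another substitution on an aromatic carbon, namely a step that the two limits leave unreadable from compound 1 to compound 2. That comparison gives no size or direction to carry over, and it shows only that adding methoxy did not bring a value inside the measurable range.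

With no evidence for a gain, the expected change is a number no higher from compound 1 to compound 3 (the limit leaves the size open), and no shift beyond the scatter is expected. For compound 3, the estimated value is 40000 nM, with an expected range of 15000 nM to 100000 nM.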

Compound 3, half-maximal inhibitory concentration: > 40000 nM
Compound 3 gave a limit, no number; the forecaster's own chance of this, stated with the estimate: 80%; the middle value sits exactly at the limit.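

In this assay compound 3 gives > 40000 nM as a limit of the assay and not a number. The steps from compound 1 to compound 2 and from compound 1 to compound 3 therefore cannot be read. The compounds shown leave open whether any change to the shared core can bring a value into the measurable range.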